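The compounds below may be only part of what the source reports. "The series", "measured", "known", "first", "only" and "open" are said of these compounds alone.

Among the three compounds measured so far, compound 2 `C=C(Br)C(=O)Nc1cccc(-c2cn3nc(-c4ccc(OCC)cc4)sc3n2)c1` stands lowest in a functional assay on FM3A cells (Mus musculus) for inhibition, read by cell counting, with a stated time of 2 days (a higher number here means a weaker inhibitor, a lower number a stronger inhibitor), where compound 2 gives 1100 nM. Compound 3 `Nc1cccc(-c2cn3nc(Cc4ccc(Cl)cc4)sc3n2)c1` lies furthest from it, and in this assay compound 3 gives 6000 nM, a difference beyond the scatter. Compound 1 `COc1ccc(-c2nn3cc(-c4cccc(N)c4)nc3s2)cc1OC` is the furthest of the three, and in this assay compound 1 gives 13000 nM, also beyond the scatter. Compounds 1 and 3 each differ from compound 2 in more than one place, so no single change can be read from those two gaps.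

Compound 4 `C=C(Br)C(=O)Nc1cccc(-c2cn3nc(-c4ccc(F)cc4)sc3n2)c1` has not yet been measured. It differs from compound 2 in one place only: fluoro in place of ethoxy on an aromatic carbon. The ethoxy group leaves and a fluoro group enters on an aromatic carbon of a six-membered aromatic ring of carbon only. Going by the values given here, no measured pair isolates this change, so there is no direct precedent within these data.

For the step from compound 2 to compound 4 the expectation is a 1.8-fold higher number from compound 2 to compound 4 (0.26 log units; within the scatter), at most a small loss and quite possibly nothing beyond the scatter. Compound 4 is therefore estimated at 2000 nM, with a range from 700 nM to 6000 nM.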

Compound 4, half-maximal inhibitory concentration: 610 nM
The estimate for compound 4 lay 3.3-fold (0.52 log units) above the measured number, outside the stated range (below it).
By their numbers in this assay, from the lowest: compounds 4 and 2 (each within the scatter of the next); then compound 3; then compound 1.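

Going by these compounds alone, this is the first pair that isolates a single change, and in this assay the exchange of 4-ethoxyphenyl for 4-fluorophenyl gives a 1.8-fold lower number from compound 2 to compound 4 (0.26 log units; within the scatter) at this position. The two compounds therefore cannot be told apart here, so the ethoxy group is not needed to keep the number at this level: the much smaller fluoro, on the same aromatic carbon, serves as well. Nothing shown accounts for why the two groups read alike.

From the compounds shown here alone, whether an amine, a carboxylic acid or a longer chain such as butoxy on this carbon would also stay within the scatter remains open. Also open, going by these compounds, is whether the same exchange would read alike in compounds carrying the free amine of compound 3 instead of the amide side chain.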